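Working notes: fluoro for chloro, compound 2 to compound 3

The source may report more compounds than this note shows. Statements on the series, on what has been measured and on what is new or still open speak of the compounds shown alone.

Measured in a functional assay on HeLa cells (Homo sapiens) for inhibition, read by sulforhodamine B assay, with a stated time of 48 h; a higher number here means a weaker inhibitor of growth, a lower number a stronger inhibitor of growth:
- compound 1 `CC(=O)OC/C(=C\C1CCCCC1)C(=O)c1ccccc1` gives 21000 nM
- compound 2 `CC(=O)OC/C(=C\c1ccc(Cl)cc1)C(=O)c1ccccc1` gives 3200 nM

Compound 2 stands at the lowest of the two numbers. Among the measured compounds shown here, the one measured step in this assay is a 6.6-fold lower number from compound 1 to compound 2 (0.82 log units; beyond the scatter). Compound 3 `CC(=O)OC/C(=C\c1ccc(F)cc1)C(=O)c1ccccc1` differs from compound 2 by fluoro in place of chloro on an aromatic carbon. For the measured compounds named here, no measured pair exchanges one halogen for another, so the single recorded step does not bear directly on this change; the two halogens are at least of the same kind of group in the same place. Compound 3 is therefore expected near compound 2, with the estimate 5000 nM (range 2000 nM to 15000 nM), a step of a 1.6-fold higher number from compound 2 to compound 3 (0.19 log units; within the scatter) that is expected to sit close to the scatter rather than clearly beyond it.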

Compound 3, concentration for 50% growth inhibition: 25000 nM
Beside the measured number, compound 3's estimate is 5.0-fold (0.70 log units) below it; the measured number lies above the stated range.
By their numbers in this assay, from the lowest: compound 2; then compounds 1 and 3 (each within the scatter of the next).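

Fluoro in place of chloro on this aromatic carbon gives a 7.8-fold higher number from compound 2 to compound 3 (0.89 log units; beyond the scatter) in this assay and so the two halogens are not interchangeable at this position. The change from cyclohexyl to 4-fluorophenyl gives a 1.2-fold higher number from compound 1 to compound 3 (0.08 log units; within the scatter) and so the earlier gain over cyclohexyl holds for 4-chlorophenyl but not for 4-fluorophenyl. As far as these compounds go, whether bromo or methoxy at this position would stay with compound 2 or with compound 3 remains open. No measured evidence accounts for the gap between the two halogens.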